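Compound 2 to compound 3: clearance expected to hold

The source may hold more compounds than are shown below. What is called first, only, known or untested is meant among the compounds shown, and "the series" means these compounds.

Values measured so far in an ADME assay on microsomes from liver (Homo sapiens) for metabolic stability, read by LC-MS, using NADPH, with a stated time of 10 min, tested at 0.1 uM; on this read-out higher numbers stand for fast clearance and lower numbers for slow clearance
- Compound 1 (`O=C(NCCCCc1ccccc1)c1cccc(C2SCC(=O)N2c2cccc(F)c2)c1`) at 1840 mL.min-1.g-1
- Compound 2 (`CC(F)(F)c1cccc(N2C(=O)CSC2c2cccc(C(=O)NCCCCc3ccccc3)c2)c1`) at 1750 mL.min-1.g-1

Among the measured compounds shown here, compound 2 stands level with compound 1, as the single measured step shows (a 1.1-fold lower number from compound 1 to compound 2 (0.02 log units; within the scatter)), which lies within the scatter. Compound 3 (`O=C(NCCCCc1ccccc1)c1cccc(C2SCC(=O)N2c2ccc(C3CC3)cc2)c1`) differs from compound 2 on an amide-type nitrogen in a ring (a group of 9 heavy atoms (9 carbon; one three-membered non-aromatic ring of carbon only, one six-membered aromatic ring of carbon only) in place of a group of 10 heavy atoms (8 carbon, 2 fluorine; one six-membered aromatic ring of carbon only), on an amide-type nitrogen in a ring). For the measured compounds named here, only that measured step bears on this change, and it also altered the group on that nitrogen. Going by the values given here, no measured compound carries a 4-cyclopropylphenyl, so the evidence is thin, and no shift beyond the scatter is expected in this assay here. The expected step is small (a 1.0-fold lower number from compound 2 to compound 3 (0.01 log units; within the scatter)). Compound 3 is estimated at 1700 mL.min-1.g-1 with an expected range of 900 mL.min-1.g-1 to 3000 mL.min-1.g-1 on this read-out.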

Compound 3, intrinsic clearance in microsomes: 811 mL.min-1.g-1
The estimate for compound 3 lay 2.1-fold (0.32 log units) above the measured number; measured number outside the range, below it.
By their numbers in this assay, from the lowest: compound 3; then compounds 2 and 1 (each within the scatter of the next).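

In this assay, the group on the amide-type nitrogen in a ring can move the number after all: 4-cyclopropylphenyl brings a 2.2-fold lower number from compound 2 to compound 3 (0.33 log units; beyond the scatter), and in place of 3-fluorophenyl it brings a 2.3-fold lower number from compound 1 to compound 3 (0.36 log units; beyond the scatter). Among the compounds shown here, compound 1 and compound 2 had stood level, so this is the first change at this position that lies beyond the scatter. Nothing measured here accounts for the step.

On these data alone, it remains open which part of the 4-cyclopropylphenyl carries the step. Also open, as far as these compounds go, is whether a morpholine or a carboxylic acid on that phenyl ring would keep the lower number.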